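The source may hold more compounds than are shown below. What is called first, only, known or untested is meant among the compounds shown, and "the series" means these compounds.

Measured compounds:
Compound 1, `O=C(O)c1csc([C@H]2CC[C@@H]3[C@@H](COc4cccc(Cl)c4)[C@H](O)C[C@@H]3O2)n1`: 6.5 nM
Compound 2, `O=C(O)c1csc([C@H]2CC[C@@H]3[C@@H](CCCOc4ccccc4)[C@H](O)C[C@@H]3O2)n1`: 10 nM

Of the two numbers in a functional assay on CHO cells for agonist activity at prostaglandin E2 receptor EP2 subtype (Homo sapiens), read by HTRF and cAMP accumulation, with a stated time of 30 min (a higher number here means that more compound is needed for the effect, a lower number that less compound is needed), compound 1 stands at the lowest; its nearest neighbour is compound 2, and the step of a 1.5-fold higher number from compound 1 to compound 2 (0.19 log units; within the scatter) lies within the scatter, so the two values cannot be told apart. Compound 3, `O=C(O)c1csc([C@H]2CC[C@@H]3[C@@H](COc4cccc(OC(F)(F)F)c4)[C@H](O)C[C@@H]3O2)n1`, has not yet been measured. It differs from compound 1 in one place: trifluoromethoxy in place of chloro on an aromatic carbon, meta to a large group. Going by the values given here, the only measured step bearing on this region is the one from compound 1 to compound 2, which changed the aryl ether portion and gave a 1.5-fold higher number from compound 1 to compound 2 (0.19 log units; within the scatter), within the scatter. Among the compounds with values here, no step changes a substituent on the aromatic ring itself. The step of a 1.2-fold higher number from compound 1 to compound 3 (0.09 log units; within the scatter) is therefore expected to stay within the scatter. For compound 3 the expected value is 8 nM, with a range from 3 nM to 25 nM.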

Compound 3, half-maximal effective concentration: 0.9 nM
Beside the measured number, compound 3's estimate is 8.9-fold (0.95 log units) above it, and the stated range ends above it.
By their numbers in this assay, from the lowest: compound 3; then compounds 1 and 2 (each within the scatter of the next).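

Swapping a single substituent on this aromatic carbon, meta to a large group, is enough to move the number in this assay beyond the scatter: trifluoromethoxy in place of chloro gives a 7.2-fold lower number from compound 1 to compound 3 (0.86 log units; beyond the scatter). Going by these compounds alone, the only earlier step, a 1.5-fold higher number from compound 1 to compound 2 (0.19 log units; within the scatter), changed the chain and the ring together and stayed within the scatter, so this is the first sign that the substituent at this place matters on its own. Nothing available explains why the number falls with this change.

From the compounds shown here alone, it remains open whether trifluoromethoxy is special here or whether methoxy, trifluoromethyl or a nitrile in the same place would do as well. Also open, going by these compounds, is whether trifluoromethoxy would give a similar step on the longer chain of compound 2.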